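Phenyl in place of prop-1-en-1-yl on compound 3

A few compounds are considered here, and "the series" means these few. Any claim that something is new, unique, unknown or untested is made for them only; others in the source may bear on it.

compound 1 `CCCOC1=CC(=O)c2ccccc2C1=O` gives 51600 nM
compound 2 `Cc1ccc(S(=O)(=O)Oc2cccc3c2C(=O)C=CC3=O)cc1` gives 9470 nM
compound 3 `C/C=C/C(=O)OC1=CC(=O)c2ccccc2C1=O` gives 37900 nM

In a functional assay on HeLa cells (Homo sapiens) for cytotoxicity (a lower number here means a stronger inhibitor, a higher number a weaker inhibitor), compound 3 stands at 37900 nM and cannot be separated from compound 1, while compound 2 shows a clearly lower number than compound 3. The next structure, compound 4 `O=C(OC1=CC(=O)c2ccccc2C1=O)c1ccccc1`, keeps the core of compound 3 and carries phenyl in place of prop-1-en-1-yl on a carbonyl carbon.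

For the measured compounds named here, only one measured step bears on this change. It is a 1.4-fold lower number from compound 1 to compound 3 (0.13 log units; within the scatter), and it also altered this side group. Going by the values given here, that step stayed small, but it says little about an added aromatic ring, since no measured compound carries phenyl at this place. So no shift beyond the scatter is expected in this assay, and the direction stays open. The expected step is a 1.1-fold lower number from compound 3 to compound 4 (0.03 log units; within the scatter) and remains only an estimate. The estimate for compound 4 is 35000 nM, with an expected range from 15000 nM to 80000 nM for the measurement.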

Compound 4, half-maximal inhibitory concentration: 55000 nM
Compound 4: the middle estimate sits 1.6-fold (0.20 log units) below what was measured, within the range that was stated.
By their numbers in this assay, from the lowest: compound 2; then compounds 3, 1 and 4 (each within the scatter of the next).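

In this assay, the step is a 1.5-fold higher number from compound 3 to compound 4 (0.16 log units; within the scatter). Compound 4 is the first compound shown with an aromatic ring at this place, so this position on the carbonyl carbon can carry phenyl, a larger group than prop-1-en-1-yl, with no shift that can be told from the scatter. Nothing measured here explains why this change leaves the number so little moved.

On these data alone, it stays open whether a group of another kind at this place, such as an amine, a carboxylic acid or a longer chain, would move the number beyond the scatter. It is equally open whether adding a group to the phenyl ring of compound 4 would do so, as no compound shown has a substituted phenyl at this position.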